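From trifluoromethyl to benzyloxycarbonyl: the step to compound 4

The source may report more compounds than this note shows. Statements on the series, on what has been measured and on what is new or still open speak of the compounds shown alone.

In a functional assay on HeLa cells (Homo sapiens) for antiproliferative activity, read by MTT assay, with a stated time of 48 h (on this read-out higher numbers stand for weaker inhibition and lower numbers for stronger inhibition), compound 1 (`Fc1ccc(-c2nn(-c3ccccc3)cc2-c2nc3ccccc3[nH]2)cc1`) gives 2330 nM, compound 2 (`Fc1ccc(-c2nn(-c3ccccc3)cc2-c2nc3cc(Br)ccc3[nH]2)cc1`) gives 4940 nM and compound 3 (`Fc1ccc(-c2nn(-c3ccccc3)cc2-c2nc3cc(C(F)(F)F)ccc3[nH]2)cc1`) gives 3520 nM. Compound 3 lies within the scatter of both others, as a 1.5-fold higher number from compound 1 to compound 3 (0.18 log units; within the scatter) and a 1.4-fold lower number from compound 2 to compound 3 (0.15 log units; within the scatter) show. Compound 4 (`O=C(OCc1ccccc1)c1ccc2[nH]c(-c3cn(-c4ccccc4)nc3-c3ccc(F)cc3)nc2c1`) carries benzyloxycarbonyl in place of trifluoromethyl on an aromatic carbon. Among the compounds with values here, no measured compound carries this group, so the evidence is indirect. The nearest guides are a 2.1-fold higher number from compound 1 to compound 2 (0.33 log units; beyond the scatter), a modest step, and a 1.5-fold higher number from compound 1 to compound 3 (0.18 log units; within the scatter), which stays within the scatter. The estimated change is a 1.1-fold higher number from compound 3 to compound 4 (0.06 log units; within the scatter), so no step beyond the scatter is expected in this assay. Compound 4 is estimated at 4000 nM, with an expected range of 1600 nM to 10000 nM.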

Compound 4, half-maximal inhibitory concentration: 23600 nM
For compound 4 the middle estimate is 5.9-fold (0.77 log units) below the measured one; measured number above the stated range.
By their numbers in this assay, from the lowest: compounds 1, 3 and 2 (each within the scatter of the next, the first and the last beyond it); then compound 4.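

In this assay, benzyloxycarbonyl at this position gives larger steps than bromo or trifluoromethyl: a 6.7-fold higher number from compound 3 to compound 4 (0.83 log units; beyond the scatter), a 4.8-fold higher number from compound 2 to compound 4 (0.68 log units; beyond the scatter) and a 10-fold higher number from compound 1 to compound 4 (1.01 log units; beyond the scatter). The position therefore responds strongly to at least one substituent, and the step from hydrogen is the only one in the series graded large. Nothing measured here accounts for the rise.

The compounds shown do not tell which part of benzyloxycarbonyl goes with the step. A carboxylic acid, a methyl ester or a benzyl ether at this place would separate the carbonyl from the added aromatic ring.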